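The source may hold more compounds than are shown below. What is called first, only, known or untested is meant among the compounds shown, and "the series" means these compounds.

Measured compounds:
compound 1 `CCCCNc1nc(N)nc(C)c1CCCN1CCCCC1`: 133 nM
compound 2 `CCCCNc1nc(N)nc(C)c1C#CCN1CCCCC1`: 3790 nM
compound 3 `CCCCNc1nc(N)nc(C)c1CCCn1ccc2ccccc21`: 1100 nM

All three were read in an assay on HEK293 cells for agonist activity at Toll-like receptor 8 (Homo sapiens), read by spectrophotometry; a lower number here means that less compound is needed, a higher number that more compound is needed for the effect. Compound 1 gives the lowest number of the three in this assay; compound 3 sits well above it and compound 2 further above still, and both gaps lie beyond the usual scatter of repeated measurements. No two of these compounds differ in a single place, so no single-change step can be traced among them; of compound 2 and compound 3 only their values can be stated, and each is higher than that of compound 1.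

Compound 4 `CCCCNc1nc(N)nc(C)c1CCCc1ccccc1` has not yet been measured. Set against compound 1 the change is phenyl in place of piperidin-1-yl on a saturated chain carbon, three bonds along the chain from an aromatic carbon. Compound 1, the only one of the three whose number is low, is also the only one carrying the piperidin-1-yl; compound 3, which does not carry it, gives 1100 nM. On that basis the step of an 11-fold higher number from compound 1 to compound 4 (1.05 log units; beyond the scatter) is expected to run toward a higher number and to exceed the scatter, the exact size being uncertain because compound 3 gives 1100 nM from a different change. For compound 4 the estimated value is 1500 nM, with an expected range from 400 nM to 6000 nM.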

Compound 4, half-maximal effective concentration: 749 nM
For compound 4 the middle estimate is 2.0-fold (0.30 log units) above the measured one; measured number inside the range.
By their numbers in this assay, from the lowest: compound 1; then compounds 4 and 3 (each within the scatter of the next); then compound 2.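

In this assay, the step of a 5.6-fold higher number from compound 1 to compound 4 (0.75 log units; beyond the scatter) gives the series its first single-place comparison, with phenyl in place of piperidin-1-yl on a saturated chain carbon, three bonds along the chain from an aromatic carbon, and the rest of the structure unchanged. The group leaving and the group entering each hold the same count of heavy atoms, so this step beyond the scatter arises without any change in that count, although the entering group has no nitrogen and no hydrogen-bond acceptor. A number is still obtained without the piperidin-1-yl, as compound 4 gives 749 nM, but nothing shown explains the size or direction of this step.

The step changes the ring nitrogen and the aromatic character together, and cyclohexyl at the same place would separate the two. Going by these compounds, how an open-chain amine such as diethylamino or a longer chain would read at this place remains open, as does whether the same exchange would give a step of like size on the chain of compound 2.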